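The source may hold more compounds than are shown below. What is called first, only, known or untested is meant among the compounds shown, and "the series" means these compounds.

Values in a functional assay (trachea) for inhibition, with Cavia porcellus as the target; on this read-out higher numbers stand for weaker inhibition and lower numbers for stronger inhibition:
- Compound 1 `CC1(C)c2ccc([N+](=O)[O-])cc2[C@@H](N2CCCC2=O)[C@H]1O`: > 20000 nM, which is a limit of the assay
- Compound 2 `CC1(C)c2ccc([N+](=O)[O-])cc2[C@@H](N2CCCCC2=O)[C@H]1O`: 350 nM
- Compound 3 `CC1(C)c2ccc(C#N)cc2[C@@H](N2CCCCC2=O)[C@@H]1O`: 270 nM

Compound 3 has one measured neighbour, compound 2, and the two values lie within the scatter of each other. Compound 4 `CC1(C)c2ccc(I)cc2[C@@H](N2CCCCC2=O)[C@@H]1O` has iodo in place of cyano on an aromatic carbon. For the measured compounds named here, the only measured step, an at least 57-fold lower number from compound 1 to compound 2 (1.75 log units; beyond the scatter), changes a different part of the molecule and says little here. Compound 2 carries nitro on that aromatic carbon and gives 350 nM, although it also differs from compound 3 in its spatial arrangement. In this assay, the expected change, a 1.3-fold higher number from compound 3 to compound 4 (0.11 log units; within the scatter), stays within the scatter, with no firm direction. For compound 4 the estimated value is 350 nM, with an expected range from 100 nM to 1500 nM.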

Compound 4, half-maximal inhibitory concentration: 300 nM
The estimate for compound 4 lay 1.2-fold (0.07 log units) above the measured number; the measured number falls inside the stated range.
By their numbers in this assay, from the lowest: compounds 3, 4 and 2 (each within the scatter of the next). At a limit, above all of these: compound 1.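

In this assay, iodo in place of cyano on an aromatic carbon gives a 1.1-fold higher number from compound 3 to compound 4 (0.05 log units; within the scatter). For the compounds shown here, this is the first comparison at this carbon with nothing else changed, since compound 2 also differs in its spatial arrangement, and it shows that cyano, a hydrogen-bond acceptor, and iodo, which is not one, can be exchanged here without a change beyond the scatter. Nothing measured here explains this result. On these data alone, what an amine or a carboxylic acid on this carbon would do remains open.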